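This account rests on a few compounds, and the source may have more. Where it says the series, first, only, none or still open, it means among the compounds named here.

In an ADME assay on Huh-7 cells (Homo sapiens) for cytotoxicity, with a stated time of 72 h (a lower number here means that less compound is tolerated, a higher number that more compound is tolerated), three compounds sharing one core have been measured. Compound 1 (`CCOc1cccc2c1S(=O)(=O)N=C2C1=C(O)[C@H](C(C)(C)C)N(CCC(C)(C)C)C1=O`) gives > 33000 nM, which is a limit. Compound 2 (`CC(C)(C)CCN1C(=O)C(C2=NS(=O)(=O)c3c(OCc4ncon4)cccc32)=C(O)[C@@H]1C(C)(C)C`) gives > 33000 nM, also a limit. Compound 3 (`CC(C)(C)CCN1C(=O)C(C2=NS(=O)(=O)c3c(CNS(C)(=O)=O)cccc32)=C(O)[C@@H]1C(C)(C)C`) gives > 33000 nM, again a limit, so no number is known for it. The three compounds thus stand together at the limit of > 33000 nM in this assay, at which 3 of the 3 values shown sit.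

Compound 4 (`CC(C)(C)CCN1C(=O)C(C2=NS(=O)(=O)c3c(CCS(C)(=O)=O)cccc32)=C(O)[C@@H]1C(C)(C)C`) is the next to be measured. Its difference from compound 3 is (methylsulfonyl)methyl in place of methanesulfonamido on a saturated chain carbon bound to an aromatic carbon. In words, (methylsulfonyl)methyl stands in place of methanesulfonamido on a saturated chain carbon bound to an aromatic carbon.

The closest evidence is a step that the two limits leave unreadable from compound 1 to compound 3 and a step that the two limits leave unreadable from compound 2 to compound 3, while a step that the two limits leave unreadable from compound 1 to compound 2 adds a third case. None of these steps has a readable size, and none brought a number into view in this assay. No step beyond the scatter is therefore expected, and the expected change is a number no higher from compound 3 to compound 4 (the limit leaves the size open). Compound 4 is estimated at 33000 nM, with an expected range from 20000 nM to 50000 nM.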

Compound 4, half-maximal cytotoxic concentration: > 33000 nM
Compound 4 was reported as a limit (the forecaster's own chance of this, stated with the estimate: 85%); the middle value lies on the limit itself.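

In this assay compound 4 gives > 33000 nM, a limit, so its steps from compound 1, compound 2 and compound 3 cannot be read. The compounds shown leave open what number any of the four would give, and whether the groups that differ among them change it at all.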